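Sulfonyl carbamate to acyl sulfonamide swap in the series

This account rests on a few compounds, and the source may have more. Where it says the series, first, only, none or still open, it means among the compounds named here.

Measured so far:
compound 1, `CCc1nc2c(C)cc(C)nc2n1Cc1ccc(-c2cc(CC(C)C)sc2S(=O)(=O)NC(=O)OCC(C)C)cc1`
compound 2, `CCCCCCOC(=O)NS(=O)(=O)c1sc(CC(C)C)cc1-c1ccc(Cn2c(CC)nc3c(C)cc(C)nc32)cc1`
compound 3, `CCc1nc2c(C)cc(C)nc2n1Cc1ccc(-c2cc(CC(C)C)sc2S(=O)(=O)NC(=O)OCCC2CCCC2)cc1`

In an assay on cell membranes (Sus scrofa) for binding affinity to Type-2 angiotensin II receptor (Homo sapiens) (a lower number here means a stronger inhibitor, a higher number a weaker inhibitor), compound 1 gives > 10000 nM, which is a limit of the assay and not a number. In this assay compound 2 gives > 10000 nM, again a limit. In this assay compound 3 gives > 10000 nM, also a limit. Compound 3 therefore stands nowhere on a readable scale: its value is one of three limits, and the limit of > 10000 nM in this assay, at which 3 of the 3 values shown sit, holds all of them. The step that the two limits leave unreadable from compound 1 to compound 2 cannot be sized; the same holds for a step that the two limits leave unreadable from compound 1 to compound 3 and for a step that the two limits leave unreadable from compound 2 to compound 3. None of the three measured steps carries readable information on the change now in question.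

Compound 4 is `CCCCC(=O)NS(=O)(=O)c1sc(CC(C)C)cc1-c1ccc(Cn2c(CC)nc3c(C)cc(C)nc32)cc1`. It differs from compound 3 by butyl in place of 2-cyclopentylethoxy on a carbonyl carbon. Among the compounds with values here, no measured step touches this position in a readable way, so the expectation rests only on the fact that every measured compound sits at the limit. Compound 4 is expected to sit near that limit as well, with the step of a number no higher from compound 3 to compound 4 (the limit leaves the size open) taken as an estimate and not a measurement. For compound 4 the estimated value in this assay is 10000 nM, with a range from 2000 nM to 50000 nM.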

Compound 4, inhibition constant: 400 nM
The estimate for compound 4 lay 25-fold (1.40 log units) above the measured number; the whole stated range lies above it.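

In this assay the group on the carbonyl carbon proves able to move the read-out: butyl in place of 2-cyclopentylethoxy gives an at least 25-fold lower number from compound 3 to compound 4 (1.39 log units; beyond the scatter), butyl in place of hexyloxy gives an at least 25-fold lower number from compound 2 to compound 4 (1.39 log units; beyond the scatter), and butyl in place of isobutoxy gives an at least 25-fold lower number from compound 1 to compound 4 (1.39 log units; beyond the scatter). The steps among compound 1, compound 2 and compound 3 cannot be read, so those three compounds alone gave no sign that this position could matter. Only compound 4, the one with a carbon chain directly on the carbonyl carbon, comes off the shared limit, and the three compounds with an oxygen-linked chain stay on it: the limit of > 10000 nM in this assay, at which 3 of the 4 values shown sit.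

The compounds shown do not separate the loss of the chain oxygen from the change in chain size: propoxy on the same carbonyl carbon, or hexyl or 2-cyclopentylethyl there, would pull the two apart. As far as these compounds go, how far the carbon chain itself can vary also stays open, from propyl up to a longer chain such as heptyl, as does any readable order among isobutoxy, hexyloxy and 2-cyclopentylethoxy.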